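This account rests on a few compounds, and the source may have more. Where it says the series, first, only, none or still open, it means among the compounds named here.

Working notes on the series: in a functional assay on MDA-MB-435 cells (Homo sapiens) for cytotoxicity, read by MTT assay, with a stated time of 72 h (on this read-out higher numbers stand for weaker inhibition and lower numbers for stronger inhibition), compound 3 (`C(=N/Nc1nc2ccccc2s1)\c1ccc(-c2ccccn2)cc1`) gives > 15100 nM, which is a limit and not a number. The two other measured compounds also stop at limits, so compound 3 cannot be ranked against them.

Compound 2 (`Clc1ccc(/C=N/Nc2nc3ccccc3s2)cc1`), with chloro in place of the pyridin-2-yl, gives > 17300 nM, also a limit. Among the measured compounds shown here, the one measured step, a step that the two limits leave unreadable from compound 2 to compound 3, therefore provides no size to carry forward.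

Compound 1 (`COc1cc(/C=N/Nc2nc3ccccc3s2)ccc1O`) is the closest guide, since it also carries a hydroxy group. In this assay, compound 1 gives > 16700 nM, again a limit.

Compound 4 (`Oc1ccc(/C=N/Nc2nc3ccccc3s2)cc1`) is the next to be read, with hydroxy in place of pyridin-2-yl on an aromatic carbon.

None of the three substituents so far has brought a number within range, so no clear gain in either direction is expected, and another limit is the likeliest result. The expected change is a step that the limit leaves unreadable from compound 3 to compound 4, which is only an estimate given that compound 3 has no exact value.

For compound 4, the estimated value is 18600 nM, with an expected range of 8000 nM to 30000 nM.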

Compound 4, half-maximal inhibitory concentration: > 18500 nM
Compound 4 gave a limit, no number; the forecaster's own chance of this, stated with the estimate: 75%; the middle value lies beyond the limit too.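

In this assay compound 4 gives > 18500 nM, which is a limit and not a number. The steps to compound 4 from compound 1, compound 2 and compound 3 therefore cannot be read. The compounds shown leave open whether any substituent on the shared core brings a measurable value in this assay, and how these substituents rank.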